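Trimming one carbon on the ester chain: an expected flat result

This account rests on a few compounds, and the source may have more. Where it says the series, first, only, none or still open, it means among the compounds named here.

Compound 1 `CCNC(=O)C1=C(C)NC(=O)NC1c1ccco1`, compound 2 `CC1=C(C(=O)NC(C)C)C(c2ccco2)NC(=O)N1` and compound 3 `CCC(CC)OC(=O)C1=C(C)NC(=O)NC1c1ccco1` share one core and differ only in the group on the carbonyl carbon. In an assay on membranes from CHO cells for displacement of a labelled ligand from adenosine receptor A1 (Homo sapiens), read by scintillation counting, with a stated time of 60 min, tested at 1 uM (a lower number here means less inhibition, a higher number more inhibition at the concentration tested (going by the name of the read-out)), compound 1 gives 2%, compound 2 gives 3% and compound 3 gives 2%. The cores of compound 2 and compound 3 differ by (pentan-3-yl)oxy in place of isopropylamino on a carbonyl carbon, and this gives a number 1 percentage points lower from compound 2 to compound 3 (within the scatter). Removing one carbon from the amide side chain, (hydrogen in place of methyl on a saturated chain carbon bound to an amide-type nitrogen and a saturated chain carbon), gives a number 1 percentage points lower from compound 2 to compound 1 (within the scatter). Compound 4 `CCC(C)OC(=O)C1=C(C)NC(=O)NC1c1ccco1` arises from compound 3 by the same kind of change, (hydrogen in place of methyl on a saturated chain carbon, two bonds along the chain from an oxygen next to a carbonyl group); here the carbon concerned is two bonds along the chain from an oxygen next to a carbonyl group rather than bound to an amide-type nitrogen and a saturated chain carbon. Because a number 1 percentage points lower from compound 2 to compound 1 (within the scatter), the expected step is no change at the digits printed from compound 3 to compound 4 (within the scatter). Compound 4 is estimated at 2% in this assay.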

Compound 4, a percentage reported as inhibition, at one concentration (the size of the read-out at that concentration, not a potency): 6%
Compound 4: middle estimate off by 4 percentage points, on the low side; low and high end bracket the measured number.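

In this assay, the new compound adds no step beyond the scatter: a number 4 percentage points higher from compound 3 to compound 4 (within the scatter), a number 3 percentage points higher from compound 2 to compound 4 (within the scatter) and a number 4 percentage points higher from compound 1 to compound 4 (within the scatter). Hydrogen in place of methyl on the amide chain and on the ester chain can be set side by side, and the two steps do not differ: the same change on two cores in this assay, a number 1 percentage points lower (within the scatter) from compound 2 to compound 1 and a number 4 percentage points higher (within the scatter) from compound 3 to compound 4, 5 percentage points apart, within the scatter of two such steps This agreement is weak support for carrying the change between cores, as neither step rises above the scatter, so it cannot show whether a real effect of this change would carry over.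

The compounds shown leave open whether any group on the carbonyl carbon moves this inhibition beyond the scatter. From the compounds shown here alone, what a longer chain or an amine in that place would give also remains open.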